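Swapping a carbonyl group for phenylsulfonyl on compound 2

The compounds below may be only part of what the source reports. "The series", "measured", "known", "first", "only" and "open" are said of these compounds alone.

Compound 2 `CC(C)(C)C(=O)OC[C@H]1O[C@@H](n2cnc3c(Cl)ncnc32)C[C@@H]1O` gives 177000 nM in an ADME assay on Huh-7 cells (Homo sapiens) for cytotoxicity, read by XTT assay (on this read-out lower numbers stand for higher toxicity in this test and higher numbers for lower toxicity in this test), and compound 3 `Cc1cc(C)c(C(=O)OC[C@H]2O[C@@H](n3cnc4c(Cl)ncnc43)C[C@@H]2O)c(C)c1` gives 91000 nM and these two values lie within the usual scatter of each other. For the measured compounds named here, they are the only two real numbers available for comparison. For compound 1 `OC[C@H]1C[C@@H](n2cnc3c(Cl)ncnc32)[C@@H]1CO` the result in this assay is a limit and not a number: > 200000 nM is all that is reported.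

Compound 4 `O=S(=O)(OC[C@H]1O[C@@H](n2cnc3c(Cl)ncnc32)C[C@@H]1O)c1ccccc1` has not yet been measured. It carries phenylsulfonyl in place of (tert-butyl)carbonyl on an oxygen on a saturated carbon, a change counted as phenylsulfonyl in place of (tert-butyl)carbonyl on an oxygen on a saturated carbon and made on the same core as compound 2.

Going by the values given here, only one measured step bears on this change. The step of a 1.9-fold lower number from compound 2 to compound 3 (0.29 log units; within the scatter) also brought in an aromatic ring in place of tert-butyl, and it stayed within the scatter. Among the compounds with values here, that step kept the carbonyl, however, and no measured compound here carries phenylsulfonyl. A single step is thin ground, and the range given here is kept wide.

The step expected here is a 1.6-fold lower number from compound 2 to compound 4 (0.21 log units; within the scatter) and no clear shift beyond the scatter is anticipated. Compound 4 is estimated at 110000 nM with an expected range from 40000 nM to 200000 nM for a single measurement.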

Compound 4, half-maximal cytotoxic concentration: 146000 nM
Estimate against measurement, compound 4: 1.3-fold (0.12 log units) below; measured number inside the range.
By their numbers in this assay, from the lowest: compounds 3, 4 and 2 (each within the scatter of the next). At a limit, above all of these: compound 1.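

In this assay, the earlier step kept the carbonyl and changed only the group attached to it, whereas this change replaces the carbonyl link itself, and the outcome is a 1.2-fold lower number from compound 2 to compound 4 (0.08 log units; within the scatter). On this oxygen on a saturated carbon, phenylsulfonyl, with its six-membered aromatic ring and its sulfur, can therefore stand in place of (tert-butyl)carbonyl without a shift beyond the scatter, so none of the steps among the three groups shown on this oxygen leaves the scatter. These values should be read with the top of the read-out in mind, where one result is a limit and not a number: the limit of > 200000 nM in this assay, at which 1 of the 4 values shown sits.

As far as these compounds go, it remains open whether an amine or a carboxylic acid carried on this same oxygen would move the number beyond the scatter, or whether a methylsulfonyl group would give the same result as phenylsulfonyl without the aromatic ring. Also open, from the compounds shown here alone, is whether the swap from (tert-butyl)carbonyl to phenylsulfonyl would behave the same way on a different core, such as that of compound 1.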